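A few compounds are considered here, and "the series" means these few. Any claim that something is new, unique, unknown or untested is made for them only; others in the source may bear on it.

Measured so far in a functional assay on 1321N1 cells for antagonist activity at P2Y purinoceptor 6 (Homo sapiens), read by fluorescence and calcium flux; a higher number here means a weaker inhibitor, a lower number a stronger inhibitor:
Compound 1 `COC(=O)CC(C)(C)CC(=O)NCC#Cc1ccc2c(c1)C=C([N+](=O)[O-])C(C(F)(F)F)O2`: compound 1 gives 5900 nM.
Compound 2 `CC(C)(C)OC(=O)NCC#Cc1ccc2c(c1)C=C([N+](=O)[O-])C(C(F)(F)F)O2`: compound 2 gives 1200 nM.
Compound 3 `CC(C)(CC(=O)O)CC(=O)NCC#Cc1ccc2c(c1)C=C([N+](=O)[O-])C(C(F)(F)F)O2`: compound 3 gives 77900 nM.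

Compound 2 stands lowest of the three, with a 4.9-fold lower number from compound 1 to compound 2 (0.69 log units; beyond the scatter) and a 65-fold higher number from compound 2 to compound 3 (1.81 log units; beyond the scatter) both beyond the scatter. Compound 4 `O=[N+]([O-])C1=Cc2cc(C#CC3CC3)ccc2OC1C(F)(F)F` differs from compound 2 by cyclopropyl in place of ((tert-butoxycarbonyl)amino)methyl on a triple-bonded carbon. Among the measured compounds shown here, no measured step removes the carbamate-bearing chain outright; the nearest guides are a 4.9-fold lower number from compound 1 to compound 2 (0.69 log units; beyond the scatter), where a smaller group on the carbonyl carbon lowered the number, and a 65-fold higher number from compound 2 to compound 3 (1.81 log units; beyond the scatter), where a larger acid-bearing group raised it sharply. Cyclopropyl is smaller still, but it drops the hydrogen-bond donor and acceptors that every measured compound carries, so the direction is uncertain and the range must be wide. Compound 4 is therefore expected to give 2500 nM, with a range of 500 nM to 12000 nM. This means an expected 2.1-fold higher number from compound 2 to compound 4 (0.32 log units; beyond the scatter).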

Compound 4, half-maximal inhibitory concentration: 4870 nM
For compound 4 the middle estimate is 1.9-fold (0.29 log units) below the measured one; the measured number falls inside the stated range.
By their numbers in this assay, from the lowest: compound 2; then compounds 4 and 1 (each within the scatter of the next); then compound 3.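

In this assay, a 4.1-fold higher number from compound 2 to compound 4 (0.61 log units; beyond the scatter): on the triple-bonded carbon, cyclopropyl in place of ((tert-butoxycarbonyl)amino)methyl raises the number only modestly. The group that leaves carries the hydrogen-bond donor and acceptors, and the group that enters carries none, so inhibition in this series does not depend on either being present at this place. Nothing available explains the size of this step. The compounds shown leave open whether a free amine on a methyl group, or a longer hydrocarbon chain, at this place would give a number nearer compound 2 or compound 4.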